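The source may report more compounds than this note shows. Statements on the series, on what has been measured and on what is new or still open speak of the compounds shown alone.

For the measured compounds named here, compound 1 `FCCOc1cccc(-c2cn([C@H]3CN4CCC3CC4)nn2)c1` is tested in an assay on HEK293 cells for displacement of a labelled ligand from Neuronal acetylcholine receptor; alpha4/beta2 (Homo sapiens), read by scintillation counting, with a stated time of 120 min (on this read-out higher numbers stand for weaker inhibition and lower numbers for stronger inhibition), where compound 1 gives 7050 nM, the highest of the two numbers measured so far. Going by the values given here, its only neighbour is compound 2 `c1ccc(COc2cccc(-c3cn([C@H]4CN5CCC4CC5)nn3)c2)cc1`, which in this assay gives 5060 nM; the step of a 1.4-fold lower number from compound 1 to compound 2 (0.14 log units; within the scatter) changes the group on the chain carbon bound to the ring oxygen and not the saturated ring. Compound 3 `FCCOc1cccc(-c2cn([C@@H]3CN4CCC3CC4)nn2)c1` differs from compound 1 only in that (the two compounds have the same atoms and bonds; at least one stereo element is drawn with a configuration in one of them and without one in the other: 1 of 3 stereo elements differ; a stereocentre at a saturated ring carbon is drawn R in compound 1 and S in compound 3). Among the compounds with values here, no measured step touches that stereocentre, so nothing here says how large or in which direction the change should act. Compound 3 is therefore expected to land near compound 1, with a wide range: 7000 nM (1500 nM to 35000 nM), a step of a 1.0-fold lower number from compound 1 to compound 3 (0.00 log units; within the scatter).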

Compound 3, inhibition constant: 1260 nM
Beside the measured number, compound 3's estimate is 5.6-fold (0.74 log units) above it; measured number below the stated range.
By their numbers in this assay, from the lowest: compound 3; then compounds 2 and 1 (each within the scatter of the next).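

In this assay, the stereocentre at a saturated ring carbon matters: drawing it S rather than R, with the same atoms and bonds, gives a 5.6-fold lower number from compound 1 to compound 3 (0.75 log units; beyond the scatter). The earlier change on the chain, a 1.4-fold lower number from compound 1 to compound 2 (0.14 log units; within the scatter), did not go beyond the scatter, so this is the first step shown to do so. This reading carries one caution: the fact that one of compounds 1 and 3 is drawn with a defined configuration and the other without, at the place where they differ

From the compounds shown here alone, it remains open whether the same stereo change gives a similar step with the phenyl of compound 2, or with an amine or a longer chain in place of the fluoromethyl.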